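The compounds below may be only part of what the source reports. "The series", "measured", "known", "first", "only" and "open" are said of these compounds alone.

Measured compounds:
compound 1, `CC(=O)c1cc(CC2CO2)c(OCCCCC#N)cc1O`: 24%
compound 2, `CCc1cc(C(C)=O)c(O)cc1OCCCCC(C)(C)C#N`: 30%

In an assay on isolated protein for binding affinity to leukotriene B4 receptor 1 (Homo sapiens), tested at 1 uM (on this read-out higher numbers stand for more inhibition at the one concentration tested (going by the name of the read-out) and lower numbers for less inhibition), compound 2 gives 30%, the higher of the two numbers shown. Compound 1 gives 24% in this assay, a number that sits within the usual scatter of the figure for compound 2, so the two cannot be told apart on this read-out. The two compounds also differ in more than one place, so no single step can be read from them.

Compound 3, `CCc1cc(C(C)=O)c(O)cc1OCCCCCCC(=O)O`, has not yet been measured in this assay. It differs from compound 2 in one place: 2-carboxyethyl in place of 1-cyano-1-methylethyl on a saturated chain carbon, four bonds along the chain from an oxygen on an aromatic ring. Among the compounds with values here, no measured pair shows what such an exchange does here, so there is nothing in the data to tie the nitrile or the acid to a direction of change. The step is therefore expected to be small, and the estimate for the move from compound 2 to compound 3 is no change at the digits printed from compound 2 to compound 3 (within the scatter), a step no larger than the scatter in either direction. Compound 3 is expected to give about 30% in this assay, with a plausible range from 10% to 55%.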

Compound 3, a percentage reported as inhibition, at one concentration (the size of the read-out at that concentration, not a potency): 38%
Compound 3: middle estimate off by 8 percentage points, on the low side; the range from low to high includes it.
By their numbers in this assay, from the lowest: compounds 1, 2 and 3 (each within the scatter of the next, the first and the last beyond it).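

Within the data shown here, putting 2-carboxyethyl in place of 1-cyano-1-methylethyl on a saturated chain carbon, four bonds along the chain from an oxygen on an aromatic ring, gives a number 8 percentage points higher from compound 2 to compound 3 (within the scatter) in this assay, the first step in this set that can be read at a single place. The exchange keeps the count of 5 heavy atoms in the group, replaces a triple bond with a double bond and adds a hydrogen-bond donor, yet this read-out does not tell compound 2 and compound 3 apart, so the position accepts this change without a measurable shift at the one concentration tested. Nothing measured here accounts for this outcome, and no independent data on the two groups are available to interpret it.

The compounds shown leave open whether a primary amide, an amine or a tetrazole at the end of the chain, or a longer chain ending in the carboxylic acid, would give a step beyond the scatter. They also leave open whether compound 2 and compound 3 would differ in a full concentration series, which a reading at one concentration cannot show.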